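The source may report more compounds than this note shows. Statements on the series, on what has been measured and on what is new or still open speak of the compounds shown alone.

Compound 1 `COc1ccc(Nc2ncc(C(F)(F)F)c(N3Cc4cccc(N(C)S(C)(=O)=O)c4C3)n2)cc1C(F)(F)F`: 14000 nM in a functional assay on HeLa cells (Homo sapiens) for antiproliferative activity, read by spectrophotometry, with a stated time of 2 days; a higher number here means a weaker inhibitor of growth, a lower number a stronger inhibitor of growth
Compound 2 `Cc1ccc(Nc2ncc(C(F)(F)F)c(N3Cc4cccc(N(C)S(C)(=O)=O)c4C3)n2)c(Cl)c1`: 10900 nM
Compound 3 `CN(c1cccc2c1CN(c1nc(Nc3cccc(C(F)(F)F)c3)ncc1C(F)(F)F)C2)S(C)(=O)=O`: 5300 nM

Compound 3 stands lowest of the three: compound 2 lies a 2.1-fold lower number from compound 2 to compound 3 (0.31 log units; beyond the scatter) and compound 1 lies a 2.6-fold lower number from compound 1 to compound 3 (0.42 log units; beyond the scatter), both beyond the scatter. Compound 4 `COc1cc(Nc2ncc(C(F)(F)F)c(N3Cc4cccc(N(C)S(C)(=O)=O)c4C3)n2)cc(C(F)(F)F)c1` differs from compound 3 by methoxy in place of hydrogen on an aromatic carbon. Going by the values given here, the one step that bears on this is a 2.6-fold lower number from compound 1 to compound 3 (0.42 log units; beyond the scatter), in which loss of a methoxy lowered the number. Here a methoxy returns, but meta to the trifluoromethyl group rather than where it sat in compound 1, so the cases are not identical. A modest rise, roughly reversing that step, is expected. Compound 4 is therefore estimated at 9000 nM, within 4000 nM to 20000 nM. That amounts to an expected step of a 1.7-fold higher number from compound 3 to compound 4 (0.23 log units; within the scatter).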

Compound 4, concentration for 50% growth inhibition: 5100 nM
For compound 4 the middle estimate is 1.8-fold (0.25 log units) above the measured one; low and high end bracket the measured number.
By their numbers in this assay, from the lowest: compounds 4 and 3 (each within the scatter of the next); then compounds 2 and 1 (each within the scatter of the next).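

Adding methoxy at this position, meta to a trifluoromethyl group, leaves the number where it was (a 1.0-fold lower number from compound 3 to compound 4 (0.02 log units; within the scatter)) in this assay. The placing of the methoxy matters: the 3-methoxy-5-(trifluoromethyl)phenyl group gives a 2.7-fold lower number from compound 1 to compound 4 (0.44 log units; beyond the scatter), and the change from the 2-chloro-4-methylphenyl group gives a 2.1-fold lower number from compound 2 to compound 4 (0.33 log units; beyond the scatter). Nothing measured here accounts for these steps. Going by these compounds, whether an amine, a carboxylic acid or a longer chain at this position would also leave the number unchanged remains open.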